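Vero cytotoxicity notes: benzamide to butyl carbamate

This account rests on a few compounds, and the source may have more. Where it says the series, first, only, none or still open, it means among the compounds named here.

Measured so far in an ADME assay on Vero cells (Chlorocebus sabaeus) for cytotoxicity, read by resazurin assay, with a stated time of 3 days; a lower number here means a stronger inhibitor, a higher number a weaker inhibitor:
compound 1 `CN(C)c1cc2[nH]c(C3CCCCC3)nc2cc1NC(=O)c1ccccc1` gives > 100 ug/mL, which is a limit of the assay.
compound 2 `CCN(CC)c1cc2[nH]c(C3CCCCC3)nc2cc1NC(=O)c1ccc(OC(F)(F)F)cc1` gives > 100 ug/mL, which is also a limit of the assay.

Compound 1 thus stands only at a limit in this assay, with no numbered value of its own. Going by the values given here, the same holds for the one further value shown, so that what can be said of the series so far is the limit of > 100 ug/mL in this assay, at which 2 of the 2 values shown sit.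

Compound 3 `CCCCOC(=O)Nc1cc2nc(C3CCCCC3)[nH]c2cc1N(C)C` has not yet been measured in this assay. Against compound 1 it carries one change: butoxy in place of phenyl on a carbonyl carbon. Among the compounds with values here, no step between two measured compounds is available to weigh this change. With both values shown sitting at the limit, compound 3 is expected to stay at that limit as well, and the step of a number no higher from compound 1 to compound 3 (the limit leaves the size open) is expected to be none beyond the scatter. For compound 3 the estimate in this assay is 100 ug/mL, in the range 50 ug/mL to 300 ug/mL.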

Compound 3, half-maximal inhibitory concentration: > 100 ug/mL
Compound 3 gave a limit, no number; the forecaster's own chance of this, stated with the estimate: 75%; the middle value lies on the limit itself.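

Going by these compounds alone, compound 1 and compound 3 both stand at a limit in this assay, and no step between them can be read. The compounds shown leave open where any of them would reach a numbered value in this assay, and whether butoxy in place of phenyl on a carbonyl carbon shifts it.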